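This account rests on a few compounds, and the source may have more. Where it says the series, first, only, none or still open, it means among the compounds named here.

Among the measured compounds shown here, in a functional assay on A549 cells (Homo sapiens) for antiproliferative activity, read by MTT assay, with a stated time of 24 h (a higher number here means a weaker inhibitor, a lower number a stronger inhibitor), compound 1 (`Cc1ccccc1NNC(=O)c1ccc(NS(=O)(=O)c2cnc(O)nc2O)cc1`) gives 14500 nM, the only true number available so far. Its close relative, compound 2 (`Cc1cccc(NNC(=O)c2ccc(NS(=O)(=O)c3cnc(O)nc3O)cc2)c1`), reads > 20000 nM, which is a limit of the assay and not a number. For the measured compounds named here, the one measured step, an at least 1.3-fold higher number from compound 1 to compound 2 (0.13 log units; that floor lies within the scatter), moves the methyl group to another place on the ring but does not replace it, so it offers little guidance here. Compound 3 (`O=C(NNc1ccccc1Cl)c1ccc(NS(=O)(=O)c2cnc(O)nc2O)cc1`) instead carries chloro in place of methyl on an aromatic carbon, ortho to a large group: chloro in place of methyl on an aromatic carbon. Going by the values given here, no measured step makes this swap, so no shift beyond the scatter is expected in this assay, and the anchor remains compound 1 at 14500 nM. The estimated change is a 1.0-fold lower number from compound 1 to compound 3 (0.02 log units; within the scatter). For compound 3, the expected value is 14000 nM, with an estimated range from 7000 nM to 20000 nM.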

Compound 3, half-maximal inhibitory concentration: 3340 nM
Estimate against measurement, compound 3: 4.2-fold (0.62 log units) above; the measured number lies below the stated range.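

In this assay, this aromatic carbon, ortho to a large group, responds clearly to what it carries: chloro in place of methyl gives a 4.3-fold lower number from compound 1 to compound 3 (0.64 log units; beyond the scatter). The earlier step only moved the methyl and its floor lay within the scatter, whereas this swap goes beyond the scatter, even though methyl and chloro match in the heavy-atom, hydrogen-bond donor and hydrogen-bond acceptor counts. Compound 2 reads at a limit of the assay and not a number, so an at least 5.9-fold lower number from compound 2 to compound 3 (0.77 log units; beyond the scatter) sets only a floor on that step: the limit of > 20000 nM in this assay, at which 1 of the 3 values shown sits.

From the compounds shown here alone, whether this shift is particular to chloro stays open, and a fluoro, bromo or methoxy group on the same carbon would test that. A 3-chlorophenyl group would show whether the shift also holds where compound 2 carries its methyl.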